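A Larger Amine on the Piperidine Tail of Compound 1

The source may report more compounds than this note shows. Statements on the series, on what has been measured and on what is new or still open speak of the compounds shown alone.

Compound 1 `CN(C)C1CCN(C(=O)CCCOc2cc(C(=O)N3CCCCc4sccc43)ccc2NC(=O)c2ccccc2-c2ccccc2)CC1`: in an assay on adrenal medulla for inhibition of Vasopressin V2 receptor (Rattus norvegicus), read by radioligand binding (a higher number here means a weaker inhibitor, a lower number a stronger inhibitor), compound 1 gives 3 nM
Compound 2 `CN1CCN(CCCCOc2cc(C(=O)N3CCCCc4sccc43)ccc2NC(=O)c2ccccc2-c2ccccc2)CC1`: in this assay compound 2 gives 7 nM
Compound 3 `COc1cc(C(=O)N2CCCC(N(C)C)c3sccc32)ccc1NC(=O)c1ccccc1-c1ccccc1`: in this assay compound 3 gives 10 nM

Among these three, compound 1 has the lowest number. Among the measured compounds shown here, its nearest neighbour is compound 2, and the step of a 2.3-fold higher number from compound 1 to compound 2 (0.37 log units; beyond the scatter) is the only measured step between compounds that differ in one place. Compound 3 differs from both in more than one place and is compared as a number only; it stands furthest from compound 1.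

Compound 4 `CCN(CC)C1CCN(C(=O)CCCOc2cc(C(=O)N3CCCCc4sccc43)ccc2NC(=O)c2ccccc2-c2ccccc2)CC1` is not yet measured. It differs from compound 1 in a single place: diethylamino in place of dimethylamino on a saturated ring carbon. For the measured compounds named here, the one measured step, a 2.3-fold higher number from compound 1 to compound 2 (0.37 log units; beyond the scatter), exchanged the whole group carrying the basic amine on the chain and moved the number only modestly. Going by the values given here, no measured pair swaps dimethylamino for diethylamino, so nothing here speaks directly to this smaller change; the measured step is the closest guide and suggests a small move at most. For compound 4 a step of a 1.3-fold higher number from compound 1 to compound 4 (0.12 log units; within the scatter) is expected, most likely within the scatter. Compound 4 is expected to give 4 nM, with a range from 1.5 nM to 12 nM.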

Compound 4, half-maximal inhibitory concentration: 6 nM
For compound 4 the middle estimate is 1.5-fold (0.18 log units) below the measured one; the measured number falls inside the stated range.
By their numbers in this assay, from the lowest: compounds 1, 4, 2 and 3 (each within the scatter of the next, the first and the last beyond it).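

The earlier compounds shown here changed the whole group carrying the amine on the chain, so they could not show what the amine's own substituents contribute; this pair changes only those substituents, on a saturated ring carbon of the piperidine. In this assay the change from 4-(dimethylamino)piperidin-1-yl to 4-(diethylamino)piperidin-1-yl gives a 2.0-fold higher number from compound 1 to compound 4 (0.30 log units; within the scatter) and so cannot be told apart from the variation between repeated measurements, which means that this position accepts the larger diethylamino group without a clear loss or gain. Nothing in the data available here offers an explanation for this result.

With only dimethylamino and diethylamino shown at this ring carbon, it remains open how much larger the group can become, for example dipropylamino, or whether the amine can be tied back into a ring, as in pyrrolidin-1-yl. Going by these compounds, it is also open whether any amine is needed at this carbon at all, a question that a compound carrying a hydroxyl group there, or just hydrogen, could answer.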